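Exchanging a side group of compound 3

The source may report more compounds than this note shows. Statements on the series, on what has been measured and on what is new or still open speak of the compounds shown alone.

In a toxicity assay on microsomes from liver (Homo sapiens) for metabolic stability, read by LC-MS, using NADPH, tested at 1 uM (a lower number here means slower removal, a higher number faster removal of the compound), compound 1 (`C[C@@H]1CN(c2scnc2-c2nc3ccccc3[nH]2)CCN1C(=O)Cn1cnc2cccnc21`) gives 12 mL.min-1.g-1 and compound 2 (`Cc1nc(-c2nc3ccccc3[nH]2)c(N2CCN(C(=O)Cn3cnc4cccnc43)[C@H](C)C2)s1`) gives 23 mL.min-1.g-1. Compound 3 (`CCOc1ncc(-c2nc(C(F)(F)F)sc2N2CCN(C(=O)Cn3ncc4cccnc43)[C@H](C)C2)cn1`) gives 41 mL.min-1.g-1, within the scatter of compound 2 and beyond the scatter of compound 1 on the higher side. Compound 4 (`CCOc1ncc(-c2nc(C(F)(F)F)sc2N2CCN(C(=O)Cn3cnc(C(F)(F)F)n3)[C@H](C)C2)cn1`) carries a group of 9 heavy atoms (3 carbon, 3 nitrogen, 3 fluorine; one five-membered aromatic ring with 3 hetero atoms) in place of a group of 9 heavy atoms (6 carbon, 3 nitrogen; one five-membered aromatic ring with 2 hetero atoms, one six-membered aromatic ring with 1 hetero atom), on a saturated chain carbon bound to a carbonyl carbon; the entering group is 3-(trifluoromethyl)-1H-1,2,4-triazol-1-yl. For the measured compounds named here, the only measured step, a 1.9-fold higher number from compound 1 to compound 2 (0.28 log units; within the scatter), concerns a different change, methyl in place of hydrogen on an aromatic carbon, so it offers no direction for this exchange. No shift beyond the scatter is therefore expected in this assay, and the estimated step is a 1.3-fold lower number from compound 3 to compound 4 (0.11 log units; within the scatter). For compound 4 the expected value is 32 mL.min-1.g-1, with an estimated range of 14 mL.min-1.g-1 to 80 mL.min-1.g-1.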

Compound 4, intrinsic clearance in microsomes: < 10 mL.min-1.g-1
Compound 4 was reported as a limit; the forecaster's own chance of this, stated with the estimate: 3%; at least 3.2-fold (0.50 log units) between middle value and limit.
By their numbers in this assay, from the lowest: compounds 1, 2 and 3 (each within the scatter of the next, the first and the last beyond it). At a limit, below all of these: compound 4.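

Compound 4 in this assay is reported as a limit, not a number: the limit of < 10 mL.min-1.g-1 in this assay, at which 1 of the 4 values shown sits. At this saturated chain carbon bound to a carbonyl carbon, 3-(trifluoromethyl)-1H-1,2,4-triazol-1-yl in place of the group with one five-membered and one six-membered aromatic ring gives an at least 4.1-fold lower number from compound 3 to compound 4 (0.61 log units; beyond the scatter). The only earlier step stayed within the scatter, so this is the first single exchange shown to move the number beyond it, with the heavy-atom count of the group unchanged.

The compounds shown do not separate the trifluoromethyl from the triazole ring; a methyl-bearing or unsubstituted 1,2,4-triazol-1-yl in this place would do so. On these data alone, the true size of the step also stays open.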